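The source may report more compounds than this note shows. Statements on the series, on what has been measured and on what is new or still open speak of the compounds shown alone.

Compound 1 `COc1ccc(N(C(=O)CN2C=CN(c3cccnc3)C(=O)C(Cc3n[nH]c4cc(F)ccc34)C2=O)C(C)C)cc1` in a functional assay on CHO cells for agonist activity at Melanocyte-stimulating hormone receptor (Homo sapiens), read by a luciferase reporter, with a stated time of 4 h (a lower number here means that less compound is needed, a higher number that more compound is needed for the effect), gives 12.6 nM. Compound 2 `O=C1C(Cc2n[nH]c3cc(F)ccc23)C(=O)N(c2ccccc2)C=CN1CC(=O)N1CCCCc2ccccc21` in this assay gives 1.59 nM.

Compound 2 holds the lower of the two numbers, and the gap to compound 1 lies beyond the usual scatter. Compound 3 `COc1ccc(N(C(=O)CN2C=CN(c3ccccc3)C(=O)C(Cc3n[nH]c4cc(F)ccc34)C2=O)C(C)C)cc1` differs from compound 2 by a group of 12 heavy atoms (10 carbon, 1 nitrogen, 1 oxygen; one six-membered aromatic ring of carbon only) in place of a group of 11 heavy atoms (10 carbon, 1 nitrogen; one six-membered aromatic ring of carbon only, one seven-membered non-aromatic ring with 1 hetero atom), on a carbonyl carbon. Among the compounds with values here, no measured pair isolates this change, so the expectation rests only on the spread between the two values seen. Compound 3 is expected to move a 3.8-fold higher number from compound 2 to compound 3 (0.58 log units; beyond the scatter) in this assay, a rise that probably exceeds the scatter. Compound 3 is estimated at 6 nM, within a range of 1.5 nM to 25 nM.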

Compound 3, half-maximal effective concentration: 1.59 nM
For compound 3 the middle estimate is 3.8-fold (0.58 log units) above the measured one; the measured number falls inside the stated range.
By their numbers in this assay, from the lowest: compounds 2 and 3 (each within the scatter of the next); then compound 1.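

In this assay, placing isopropyl(4-methoxyphenyl)amino on the carbonyl carbon in place of the group with the seven-membered ring gives no change at the digits printed from compound 2 to compound 3 (within the scatter) and so does not separate these two groups. Phenyl in place of pyridin-3-yl on the amide-type nitrogen in a ring gives a 7.9-fold lower number from compound 1 to compound 3 (0.90 log units; beyond the scatter). Nothing available gives a reason for either result. As far as these compounds go, whether pyridin-4-yl or 4-fluorophenyl on that ring nitrogen would match phenyl remains open. So does whether a small dimethylamino group on the carbonyl carbon would keep the number.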